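Shortening the Chain Again on a Nucleotide Series

The source may hold more compounds than are shown below. What is called first, only, known or untested is meant among the compounds shown, and "the series" means these compounds.

Compound 1 `Nc1ncnc2c1nc(NCCCCCCCCNC(=O)CI)n2[C@@H]1O[C@H](COP(=O)(O)OP(=O)(O)OP(=O)(O)O)[C@@H](O)[C@H]1O` and compound 2 `Nc1ncnc2c1nc(NCCCCCCNC(=O)CI)n2[C@@H]1O[C@H](COP(=O)(O)OP(=O)(O)OP(=O)(O)O)[C@@H](O)[C@H]1O` share one core and differ only in the length of the chain carrying the ((iodomethyl)carbonyl)amino group. In an assay on isolated protein for inhibition of hexokinase-1 (Rattus norvegicus), with a stated time of 6 h, tested at 10 mM (on this read-out lower numbers stand for less inhibition and higher numbers for more inhibition at the one concentration tested (going by the name of the read-out)), compound 1 gives 0%, and compound 2 gives 0%; the step of no change at the digits printed from compound 1 to compound 2 (within the scatter) was flat. Compound 2 therefore stands level with compound 1. Compound 3 `Nc1ncnc2c1nc(NCCNC(=O)CI)n2[C@@H]1O[C@H](COP(=O)(O)OP(=O)(O)OP(=O)(O)O)[C@@H](O)[C@H]1O` shortens the chain once more: ((iodomethyl)carbonyl)amino in place of 4-(((iodomethyl)carbonyl)amino)butyl on a saturated chain carbon, two bonds along the chain from a nitrogen on an aromatic ring. For the measured compounds named here, only the step from compound 1 to compound 2 bears on this change, and it showed nothing beyond the scatter. For compound 3 the expected step in this assay is no change at the digits printed from compound 2 to compound 3 (within the scatter), none beyond the scatter. Compound 3 is estimated at 0%, between 0% and 10%.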

Compound 3, a percentage reported as inhibition, at one concentration (the size of the read-out at that concentration, not a potency): 0%
Compound 3: middle estimate and measured number agree at the digits printed, within the range that was stated.
By their numbers in this assay, from the lowest: compounds 1, 2 and 3 (each within the scatter of the next).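

In this assay the chain now reaches its shortest form here, 2-(((iodomethyl)carbonyl)amino)ethyl, and the last cut gives no change at the digits printed from compound 2 to compound 3 (within the scatter). Taken over the whole shortening, the result is no change at the digits printed from compound 1 to compound 3 (within the scatter), so the flat read-out now holds across all three chain lengths, and chain length at this position does not separate these compounds. Nothing measured here explains this flat result. The compounds shown leave open whether a chain longer than that of compound 1 would move the read-out. They also leave open whether an amine or a carboxylic acid in place of the ((iodomethyl)carbonyl)amino group would do so.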